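From a Branched Alkene Ether to a Cyclohexyl Ether

The source may report more compounds than this note shows. Statements on the series, on what has been measured and on what is new or still open speak of the compounds shown alone.

Compound 1 `CCOCC(C)Oc1cccc2ccc(N)nc12` gives 1070 nM in an assay on cells with melanin-concentrating hormone receptor 1 (Homo sapiens) as the target, read by radioligand binding; on this read-out lower numbers stand for stronger inhibition and higher numbers for weaker inhibition.
Compound 2 `COCC(C)Oc1cccc2ccc(N)nc12` gives 606 nM in this assay.
Compound 3 `CC(C)=CCOc1cccc2ccc(N)nc12` gives only > 2000 nM in this assay, a limit of the assay.

Compound 3 thus sits at the limit of > 2000 nM in this assay, at which 1 of the 3 values shown sits, the weakest position among the three numbers shown. The steps into it were an at least 1.8-fold higher number from compound 1 to compound 3 (0.27 log units; that floor lies within the scatter) and an at least 3.3-fold higher number from compound 2 to compound 3 (0.51 log units; beyond the scatter), both toward weaker inhibition. Compound 4 `Nc1ccc2cccc(OC3CCCCC3)c2n1` differs from compound 3 by cyclohexyl in place of 3-methylbut-2-en-1-yl on an oxygen on an aromatic ring. Both measured steps bearing on compound 3 point to an oxygen-free side group giving weaker numbers than the ether-containing groups of compound 1 and compound 2, and compound 4 keeps an oxygen-free group. The author therefore expects no step beyond the scatter for compound 4, a step that the limit leaves unreadable from compound 3 to compound 4. The estimate for compound 4 in this assay is 3000 nM, with a range from 1200 nM to 8000 nM.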

Compound 4, half-maximal inhibitory concentration: 361 nM
The estimate for compound 4 lay 8.3-fold (0.92 log units) above the measured number, and the stated range ends above it.
By their numbers in this assay, from the lowest: compounds 4, 2 and 1 (each within the scatter of the next, the first and the last beyond it). At a limit, above all of these: compound 3.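

In this assay, cyclohexyl in place of 3-methylbut-2-en-1-yl on the oxygen on the aromatic ring gives an at least 5.5-fold lower number from compound 3 to compound 4 (0.74 log units; beyond the scatter). The value of compound 3 is a limit of the assay, so this step has only a floor. The earlier link between an oxygen-free group and weaker numbers therefore does not hold for compound 4, which shows a 3.0-fold lower number from compound 1 to compound 4 (0.47 log units; beyond the scatter) and a 1.7-fold lower number from compound 2 to compound 4 (0.22 log units; within the scatter), while compound 3 alone still fits it. The compounds shown leave open whether cyclopentyl or cycloheptyl on this oxygen would give similar numbers. They also leave open what a piperidinyl or tetrahydropyranyl ring would do there.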